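Inverting One Stereocentre in a Cell Viability Series

The source may report more compounds than this note shows. Statements on the series, on what has been measured and on what is new or still open speak of the compounds shown alone.

Compound 1 `COC(=O)/C=C\NC(=O)[C@H](O)C(C)(C)CO`: "not determined" (no result reported)
Compound 2 `CC(C)(C)OC(=O)/C=C\NC(=O)[C@H](O)C(C)(C)CO`: -14%
Compound 3 `CC(C)(CO)[C@@H](O)C(=O)N/C=C\C(=O)OCc1ccccc1`: 4%

In an ADME assay on WI-38 cells (Homo sapiens) for inhibition, read by CellTiter-Glo, with a stated time of 48 h, tested at 100 uM (a higher number here means more inhibition at the concentration tested (going by the name of the read-out), a lower number less inhibition), compound 3 stands highest of the two numbers shown, with compound 2 the nearest of them; compound 1 has no number reported. Going by the values given here, the only measured step, a number 18 percentage points higher from compound 2 to compound 3 (beyond the scatter), exchanged one ester group for another and moved the read-out beyond the scatter. Compound 4 `CC(C)(CO)[C@H](O)C(=O)N/C=C\C(=O)OCc1ccccc1` differs from compound 3 in one way: the two compounds have the same atoms and bonds and differ only in configuration as drawn: 1 of 2 stereo elements differ; a stereocentre at a saturated chain carbon is drawn R in compound 3 and S in compound 4. No measured step involves a change of configuration alone, so nothing among these compounds bears directly on this change, and the ester step offers no guide to it. A step of no more than the usual scatter is therefore expected for no change at the digits printed from compound 3 to compound 4 (within the scatter). Compound 4 is accordingly estimated at 4%, within -10% to 18%.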

Compound 4, a percentage reported as inhibition, at one concentration (the size of the read-out at that concentration, not a potency): -2%
Beside the measured number, compound 4's estimate is 6 percentage points above it, within the range that was stated.
By their numbers in this assay, from the lowest: compound 2; then compounds 4 and 3 (each within the scatter of the next).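

In this assay, the drawn change from R to S at a saturated chain carbon comes with a number 6 percentage points lower from compound 3 to compound 4 (within the scatter), so with the benzyl ester in place, this stereocentre leaves the read-out within the scatter. The earlier ester step could not show this, since it changed no configuration. The comparison isolates a single structural difference: the fact that compounds 3 and 4 differ only in the configuration as drawn

The compounds shown leave open whether the same holds with the tert-butyl ester of compound 2. They also leave open what a carboxylic acid in place of the ester would give.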